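A few compounds are considered here, and "the series" means these few. Any claim that something is new, unique, unknown or untested is made for them only; others in the source may bear on it.

Measured compounds:

Compound 1 `COc1ccc(NC(=O)/C=C/c2coc3cc(OC)ccc3c2=O)cc1` — in a functional assay on Huh-7 cells (Homo sapiens) for inhibition, read by MTT assay, with a stated time of 48 h (a lower number here means a stronger inhibitor, a higher number a weaker inhibitor), compound 1 gives > 100000 nM, which is a limit of the assay.
Compound 2 `COc1ccc(NC(=O)/C=C/c2coc3cc(O)ccc3c2=O)cc1` — in this assay compound 2 gives > 100000 nM, again a limit.
Compound 3 `Cc1ccccc1NC(=O)/C=C/c1coc2cc(O)ccc2c1=O` — in this assay compound 3 gives 11100 nM.

Within the data shown here, compound 3 therefore carries the only number in the set; the other two sit at the limit of > 100000 nM in this assay, at which 2 of the 3 values shown sit. The cores of compound 2 and compound 3 differ by 2-methylphenyl in place of 4-methoxyphenyl on an amide-type nitrogen, and that change gives an at least 9.0-fold lower number from compound 2 to compound 3 (0.95 log units; beyond the scatter). Compound 2 and compound 1 differ by methyl in place of hydrogen on an oxygen on an aromatic ring, and that step is a step that the two limits leave unreadable from compound 2 to compound 1.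

Compound 4 `COc1ccc2c(=O)c(/C=C/C(=O)Nc3ccccc3C)coc2c1` is not yet measured. It differs from compound 3 by methyl in place of hydrogen on an oxygen on an aromatic ring, the same change, at the same place, as from compound 2 to compound 1. Among the measured compounds shown here, the only prior instance of this change is unreadable, so the expectation for compound 4 rests on compound 3 at 11100 nM with no clear direction for the step. The step from compound 3 to compound 4 is expected to be a 1.8-fold higher number from compound 3 to compound 4 (0.26 log units; within the scatter). Compound 4 is estimated at 20000 nM in this assay, within 5000 nM to 100000 nM.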

Compound 4, half-maximal inhibitory concentration: 26900 nM
Estimate against measurement, compound 4: 1.3-fold (0.13 log units) below; low and high end bracket the measured number.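

In this assay, hydroxy to methoxy gives a 2.4-fold higher number from compound 3 to compound 4 (0.38 log units; beyond the scatter), while the same change on the 4-methoxyphenyl amide cannot be read, with a limit at both ends. Placing 2-methylphenyl in place of 4-methoxyphenyl on the amide-type nitrogen gives an at least 3.7-fold lower number from compound 1 to compound 4 (0.57 log units; beyond the scatter), so this change lowers the number on both the hydroxy and the methoxy core: the same change on two cores in this assay, an at least 9.0-fold lower number (0.95 log units; beyond the scatter) from compound 2 to compound 3 and an at least 3.7-fold lower number (0.57 log units; beyond the scatter) from compound 1 to compound 4; the limit leaves it open whether they differ The direction therefore carries across these two cores, but nothing shows that the size carries too, and compound 1 and compound 2 both stand at a limit rather than at a number: the limit of > 100000 nM in this assay, at which 2 of the 4 values shown sit.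

On these data alone, it remains open whether hydroxy to methoxy would give a step of similar size with other groups on the amide-type nitrogen, such as an unsubstituted phenyl or a chlorophenyl. Also open, as far as these compounds go, is how a longer chain on the ring oxygen, such as ethyl, or an amine or carboxylic acid on the phenyl would read in this assay.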